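Urea Replaces Amide on a Straight Chain

The compounds below may be only part of what the source reports. "The series", "measured", "known", "first", "only" and "open" are said of these compounds alone.

Compound 1 `CCC(=O)NC[C@@H]1CC1c1cccc2oc(CCCCc3ccccc3)cc12` gives 2.1 nM in an assay on NIH3T3 cells for binding affinity to melatonin receptor type 1A (Homo sapiens); on this read-out higher numbers stand for weaker inhibition and lower numbers for stronger inhibition; compound 2 `CCNC(=O)NC[C@@H]1C[C@H]1c1cccc2oc(CCCCc3ccccc3)cc12` gives 33 nM; compound 3 `CC(=O)NCCCc1cccc2oc(CCCCc3ccccc3)cc12` gives 19 nM.

Compound 1 has the lowest number of the three, with compound 3 nearest and compound 2 furthest. Compound 4 `CCNC(=O)NCCCc1cccc2oc(CCCCc3ccccc3)cc12` differs from compound 1 by 3-((ethylcarbamoyl)amino)propyl in place of 2-((propanoylamino)methyl)cyclopropyl on an aromatic carbon. Among the measured compounds shown here, the only single step measured, a 9.0-fold higher number from compound 1 to compound 3 (0.96 log units; beyond the scatter), opens the ring to a chain and weakens binding. Compound 2, which keeps the ring but carries the urea, shows a higher number than compound 1. Both changes together are therefore expected to weaken binding further, and the step of a 71-fold higher number from compound 1 to compound 4 (1.85 log units; beyond the scatter) is estimated. Compound 4 is expected to give 150 nM, in the range 40 nM to 600 nM.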

Compound 4, inhibition constant: 21 nM
The estimate for compound 4 lay 7.1-fold (0.85 log units) above the measured number; measured number below the stated range.
By their numbers in this assay, from the lowest: compound 1; then compounds 3, 4 and 2 (each within the scatter of the next).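

On the straight 3-carbon chain, putting ethylamino in place of methyl on the carbonyl carbon, which turns the amide into a urea, changes nothing beyond the scatter: a 1.1-fold higher number from compound 3 to compound 4 (0.04 log units; within the scatter). The full replacement on this aromatic carbon, a 10-fold higher number from compound 1 to compound 4 (1.00 log units; beyond the scatter), therefore costs about as much as opening the ring alone, and the urea adds no further loss on the chain. No measured evidence here accounts for this result. Still open, from the compounds shown here alone, is how a longer chain carrying the same urea, or a carboxylic acid in place of the urea, would bind.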